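This account rests on a few compounds, and the source may have more. Where it says the series, first, only, none or still open, it means among the compounds named here.

The study measures cytotoxicity in a functional assay on B16-F10 cells (Mus musculus) for cytotoxicity; a lower number here means a stronger inhibitor, a higher number a weaker inhibitor. Compound 1 `O=c1cc(O)c2cc(Cl)ccc2o1` gives 70700 nM in this assay. Compound 2 `O=c1oc2ccccc2c2nc3c(ccc4cc[nH]c43)c(-c3ccc(Cl)cc3)c12` gives 70700 nM in this assay, and compound 3 `O=c1oc2ccccc2c2nc3c(ccc4cc[nH]c43)c(-c3ccc([N+](=O)[O-])cc3)c12` gives 70700 nM in this assay. Compound 2 thus stands level with compounds 1 and 3, all three values sitting within the scatter of one another, so none of the three can be called stronger or weaker than another. Among the measured compounds shown here, the single step measured between neighbours, no change at the digits printed from compound 2 to compound 3 (within the scatter), shows that nitro in place of chloro on an aromatic carbon leaves the read-out where it was.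

Compound 4 `O=c1oc2ccccc2c2nc3c(ccc4cc[nH]c43)c(-c3c(Cl)cccc3Cl)c12` differs from compound 2 in one place: 2,6-dichlorophenyl in place of 4-chlorophenyl on an aromatic carbon. For the measured compounds named here, no measured step involves a 2,6-dichlorophenyl group, so the only guidance is the flat behaviour of the three measured compounds, where even compound 1, a far simpler structure, sits at the same value as compound 2. Compound 4 is therefore expected to show no step beyond the scatter, estimated as no change at the digits printed from compound 2 to compound 4 (within the scatter). The estimate for compound 4 is 70700 nM, expected to fall between 25000 nM and 150000 nM.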

Compound 4, half-maximal inhibitory concentration: 70700 nM
Beside the measured number, compound 4's estimate shows no gap at the digits printed, and the stated range covers the measured number.
By their numbers in this assay, from the lowest: compounds 1, 2, 3 and 4 (each within the scatter of the next).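

At the aromatic carbon opposite the ring nitrogen, 2,6-dichlorophenyl in place of 4-chlorophenyl gives no change at the digits printed from compound 2 to compound 4 (within the scatter) in this assay and, in place of 4-nitrophenyl, gives no change at the digits printed from compound 3 to compound 4 (within the scatter) on the same read-out. Among the compounds shown here, the earlier step compared only two phenyl groups each bearing one substituent at the 4-position, whereas these steps show that a phenyl group carrying two chlorines in the 2,6-pattern and none at the 4-position also stays within the scatter of both, so the flat reading at this position now covers a change in substitution pattern as well as a change of substituent. No supporting measurement bears on why these compounds read level.

All the groups shown at this position are substituted phenyl rings, so it remains open how the shared core would read with an amine, a carboxylic acid or a longer alkyl chain there in place of the ring. On these data alone, it also remains open whether a methoxy or hydroxyl group on the phenyl ring, or any change elsewhere on the shared core, would produce a step beyond the scatter.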